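Swapping a Benzoyl Phenyl for a Butyl Chain

The compounds below may be only part of what the source reports. "The series", "measured", "known", "first", "only" and "open" are said of these compounds alone.

Three close relatives share one core and differ only in the group on a carbonyl carbon next to an amide-type nitrogen. Compound 1 `CC(=O)NCC(=O)N(C)c1ccc(Cl)cc1C(=O)c1ccccc1Cl` carries a methyl there; in a functional assay on the whole organism with Mus musculus as the target, in the rotarod test (a higher number here means that more compound is needed for the effect, a lower number that less compound is needed), compound 1 gives 58 mg/kg. Compound 2 `CN(C(=O)CNC(=O)c1ccccc1)c1ccc(Cl)cc1C(=O)c1ccccc1Cl` carries a phenyl instead. In this assay compound 2 reaches only the limit of the test, > 100 mg/kg, so no number is known for it (the limit of > 100 mg/kg in this assay, at which 1 of the 2 values shown sits). The step of an at least 1.7-fold higher number from compound 1 to compound 2 (0.23 log units; that floor lies within the scatter) therefore reads as a floor, and that floor lies within the scatter. Compound 3 `CCCCC(=O)NCC(=O)N(C)c1ccc(Cl)cc1C(=O)c1ccccc1Cl` takes the change (butyl in place of phenyl on a carbonyl carbon). Going by the values given here, only the single step from methyl to phenyl bears on it, and it hardly left the scatter, so for compound 3 a modest move downward in this assay is expected, an at least 1.2-fold lower number from compound 2 to compound 3 (0.09 log units; that floor lies within the scatter), though the limit on compound 2 leaves the size uncertain. Compound 3 is estimated at 80 mg/kg, within a range from 40 mg/kg to 160 mg/kg.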

Compound 3, dose for half-maximal effect: 90 mg/kg
Compound 3: the middle estimate sits 1.1-fold (0.05 log units) below what was measured; the range from low to high includes it.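

Compound 3 shows that a longer open chain on this carbonyl carbon still gives a measured number in this assay, and going from methyl to butyl here amounts to a 1.6-fold higher number from compound 1 to compound 3 (0.19 log units; within the scatter), so compound 1 and compound 3 cannot be told apart. Putting butyl in place of the phenyl gives an at least 1.1-fold lower number from compound 2 to compound 3 (0.04 log units; that floor lies within the scatter), which is only a floor and does not say how far apart compound 2 and compound 3 really lie. Compound 2 remains a limit of the test and not a number: the limit of > 100 mg/kg in this assay, at which 1 of the 3 values shown sits.

As far as these compounds go, only methyl and butyl represent open chains at this position, so it remains open whether a longer chain such as hexyl would shift the number in this assay. From the compounds shown here alone, it is also open how a saturated ring such as cyclohexyl, or a chain ending in an amine, would compare with the phenyl of compound 2.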